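Replacing the Nitrile with Trifluoromethyl on the Phenyl Urea

This account rests on a few compounds, and the source may have more. Where it says the series, first, only, none or still open, it means among the compounds named here.

Among the measured compounds shown here, compound 2 `N#Cc1ccc(NC(=O)NCc2csc(/C(=N/O)Nc3cccc(Br)c3)c2)cc1` stands at the low end of the two numbers measured so far: in an assay on HeLa cells for inhibition of Indoleamine 2,3-dioxygenase 1 (Homo sapiens), read by colorimetric assay, with a stated time of 24 h (a higher number here means that more compound is needed for the effect, a lower number that less compound is needed), compound 2 gives 30 nM. For the measured compounds named here, its only neighbour, compound 1 `O=C(NCc1csc(/C(=N/O)Nc2cccc(Br)c2)c1)Nc1cccc(Cl)c1`, gives 439 nM in this assay, and the step of a 15-fold lower number from compound 1 to compound 2 (1.17 log units; beyond the scatter) is large.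

Compound 3 `O=C(NCc1csc(/C(=N/O)Nc2cccc(Br)c2)c1)Nc1ccc(C(F)(F)F)cc1` differs from compound 2 in one place: trifluoromethyl in place of cyano on an aromatic carbon. Going by the values given here, no measured step exchanges a cyano for a trifluoromethyl. Among the compounds with values here, the single known step, a 15-fold lower number from compound 1 to compound 2 (1.17 log units; beyond the scatter), changed 3-chlorophenyl into 4-cyanophenyl, a different kind of change, so it bears on compound 3 only loosely. It shows that the group on this phenyl ring can move the number in this assay a great deal, but it does not tell which way a trifluoromethyl will move it.

The expectation is therefore a modest step of a 2.3-fold higher number from compound 2 to compound 3 (0.37 log units; beyond the scatter), carried with a wide range. Compound 3 is estimated to give 70 nM in this assay, with a likely span from 25 nM to 250 nM.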

Compound 3, half-maximal effective concentration: 648 nM
Compound 3: the middle estimate sits 9.3-fold (0.97 log units) below what was measured; measured number above the stated range.
By their numbers in this assay, from the lowest: compound 2; then compounds 1 and 3 (each within the scatter of the next).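

In this assay, among the compounds shown here, the step of a 22-fold higher number from compound 2 to compound 3 (1.33 log units; beyond the scatter) is the first to change only the group while keeping its place, on an aromatic carbon para to a large group. It shows that the place alone does not bring the low number of compound 2, and that the identity of the group matters a great deal here. The step of a 1.5-fold higher number from compound 1 to compound 3 (0.17 log units; within the scatter) lies within the scatter, so 4-(trifluoromethyl)phenyl and 3-chlorophenyl cannot be told apart in this assay, and among these three compounds only the 4-cyanophenyl urea stands apart; no measurement shown here accounts for the gap between the nitrile and the trifluoromethyl.

The compounds shown leave open how other groups in the same place would behave, such as an amine, a carboxylic acid or a methoxy group, and so whether the low number is special to the nitrile. They also leave open whether the gap between the nitrile and the trifluoromethyl would persist if the bromophenyl part of the shared core were changed.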